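Swapping selenium for sulfur on a shared core

A few compounds are considered here, and "the series" means these few. Any claim that something is new, unique, unknown or untested is made for them only; others in the source may bear on it.

Three compounds have been measured in an ADME assay on MCF-10A cells (Homo sapiens) for cytotoxicity, read by MTT assay, with a stated time of 72 h; a higher number here means a weaker inhibitor of growth, a lower number a stronger inhibitor of growth:

Compound 1, `C[Se]/C(=N\C(=O)c1cc2ccccc2s1)NC(=O)c1cc2ccccc2s1`, gives 34700 nM.
Compound 2, `CS/C(=N\C(=O)c1cc2ccccc2s1)NC(=O)c1cc2ccccc2s1`, gives 5600 nM.
Compound 3, `C[Se]/C(=N\C(=O)c1cnc2ccccc2c1)NC(=O)c1cnc2ccccc2c1`, gives 52100 nM.

Compounds 1 and 2 share one core and differ only by a group of 2 heavy atoms (1 carbon, 1 sulfur; no ring) in place of a group of 2 heavy atoms (1 carbon, 1 selenium; no ring), on a carbon with a double bond to nitrogen. That single change produced a 6.2-fold lower number from compound 1 to compound 2 (0.79 log units; beyond the scatter), a step beyond the usual scatter. Compound 3 carries a different core; how the two cores differ is not broken down here, so compounds 1 and 3 can only be compared by their two values, which lie within the scatter of each other.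

Compound 4, `CS/C(=N\C(=O)c1cnc2ccccc2c1)NC(=O)c1cnc2ccccc2c1`, is the not yet measured partner of compound 3. It arises by a group of 2 heavy atoms (1 carbon, 1 sulfur; no ring) in place of a group of 2 heavy atoms (1 carbon, 1 selenium; no ring), on a carbon with a double bond to nitrogen. The surroundings of the place are described in the same words as for the earlier pair, so this is the same change, not merely the same kind.

Among the measured compounds shown here, the expectation rests on the one earlier step of a 6.2-fold lower number from compound 1 to compound 2 (0.79 log units; beyond the scatter) and on nothing else, since a single example cannot show how far the effect carries over to another core. For compound 4 the expected step is a 6.2-fold lower number from compound 3 to compound 4 (0.79 log units; beyond the scatter). Compound 4 is therefore estimated at 8400 nM in this assay, with a plausible range from 3500 nM to 20000 nM.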

Compound 4, concentration for total growth inhibition: 42200 nM
For compound 4 the middle estimate is 5.0-fold (0.70 log units) below the measured one, and the stated range ends below it.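

In this assay, putting methylsulfanyl in place of the selenium-bearing group on the second core gives a 1.2-fold lower number from compound 3 to compound 4 (0.09 log units; within the scatter), so on this core the swap makes no clear difference. The size of the step therefore did not carry over from one core to the other, and the core matters for what this swap does in this series: the same change on two cores in this assay, a 6.2-fold lower number (0.79 log units; beyond the scatter) from compound 1 to compound 2 and a 1.2-fold lower number (0.09 log units; within the scatter) from compound 3 to compound 4, 5.0-fold (0.70 log units) apart, beyond the scatter of two such steps. Among the compounds shown here, this shows that a step seen on one core cannot simply be added to another core here, but with only two pairs it does not show why the steps differ, or which of the two is the more usual result.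

The compounds shown leave open how the swap behaves on any further core, such as one carrying an amine or a carboxylic acid. They also leave open whether a longer chain, such as ethyl in place of the methyl on the sulfur or selenium, would widen or narrow the gap between the two steps.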